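The compounds below may be only part of what the source reports. "The series", "measured", "known", "first", "only" and "open" are said of these compounds alone.

Measured so far:
compound 1 `C=C1[C@@H](OC(C)=O)C[C@@H]2[C@](C)(CO[Si](C)(C)C(C)(C)C)[C@H](OC(C)=O)CC[C@@]2(C)[C@@H]1C[C@@H](Nc1ccc(OC)cc1)C1=CCOC1=O` — 4810 nM
compound 2 `C=C1[C@@H](OC(C)=O)C[C@@H]2[C@](C)(COC=O)[C@H](OC(C)=O)CC[C@@]2(C)[C@@H]1C[C@@H](Nc1ccc(OC)c(OC)c1)C1=CCOC1=O` — > 50000 nM

In a functional assay on A549 cells (Homo sapiens) for cytotoxicity, read by sulforhodamine B assay (on this read-out lower numbers stand for stronger inhibition and higher numbers for weaker inhibition), compound 1 gives 4810 nM. For compound 2 the same assay returns only a limit, > 50000 nM, and not a number. Compound 2 thus sits at the limit of > 50000 nM in this assay, at which 1 of the 2 values shown sits, so where it truly stands beyond that point is open.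

Compound 3 `C=C1[C@@H](OC(C)=O)C[C@@H]2[C@](C)(COC=O)[C@H](OC(C)=O)CC[C@@]2(C)[C@@H]1C[C@@H](Nc1ccc(OC)cc1)C1=CCOC1=O` is the next case to go into this assay. It differs from compound 2 in one place: hydrogen in place of methoxy on an aromatic carbon. The remainder of compound 2, including the formate on the core, is kept unchanged in compound 3.

Within the data shown here, no step between measured compounds is available, so the size and direction of this change can only be expected, not read off. Compound 1 carries the same (4-methoxyphenyl)amino group and gives 4810 nM, but its core differs from that of compound 3 in another place, so it is a loose guide at best. The expectation is a step toward stronger inhibition from compound 2 to compound 3 of about an at least 2.5-fold lower number from compound 2 to compound 3 (0.39 log units; beyond the scatter), with a fair chance that compound 3 also reaches only a limit. Compound 3 is estimated at 20000 nM, within 5000 nM to 60000 nM.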

Compound 3, half-maximal inhibitory concentration: 28900 nM
Compound 3: middle estimate off by 1.4-fold (0.16 log units), on the low side; the measured number falls inside the stated range.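

In this assay, hydrogen in place of methoxy, the change from 3,4-dimethoxyphenyl to 4-methoxyphenyl, gives an at least 1.7-fold lower number from compound 2 to compound 3 (0.23 log units; that floor lies within the scatter), so this aromatic carbon now has a measured step, though only as a floor on its size. Compound 2 gives a limit and not a number: the limit of > 50000 nM in this assay, at which 1 of the 3 values shown sits.

With the (4-methoxyphenyl)amino group held fixed, a group of 2 heavy atoms in place of the group of 7 heavy atoms on the oxygen on a saturated carbon gives a 6.0-fold higher number from compound 1 to compound 3 (0.78 log units; beyond the scatter), which shows that this second site on the core also moves the number in this assay.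

As far as these compounds go, how large the methoxy step truly is stays open, as does whether it would hold with the group of 7 heavy atoms on the core instead of the formate. Also open, from the compounds shown here alone, is how other groups would read at the same aromatic carbon, such as fluorine, hydroxyl or an amine, and how a free hydroxyl would read in place of the formate on the core.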